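Chloro to methyl on a pair sitting at the limit

A few compounds are considered here, and "the series" means these few. Any claim that something is new, unique, unknown or untested is made for them only; others in the source may bear on it.

Compound 1, `C#CCn1cc(C(=O)NCCCOC(=O)[C@H]2CCCN2C(=O)OC(C)(C)C)c(=O)c2ccc(Cl)nc21`: > 10000 nM
Compound 2, `C#CCn1cc(C(=O)NCCCOC(=O)[C@H](C)NC(=O)OC(C)(C)C)c(=O)c2ccc(Cl)nc21`: > 10000 nM

In a functional assay on KB cells (Homo sapiens) for cytotoxicity, read by MTT assay, with a stated time of 72 h (on this read-out higher numbers stand for weaker inhibition and lower numbers for stronger inhibition), compound 1 gives only a limit, > 10000 nM. Compound 2 likewise reaches only a limit in this assay, > 10000 nM. The step that the two limits leave unreadable from compound 1 to compound 2 cannot be read because both values sit at the limit of > 10000 nM in this assay, at which 2 of the 2 values shown sit. Compound 3, `C#CCn1cc(C(=O)NCCCOC(=O)[C@H]2CCCN2C(=O)OC(C)(C)C)c(=O)c2ccc(C)nc21`, differs from compound 1 by methyl in place of chloro on an aromatic carbon. Among the compounds with values here, no measured step bears on this change, and compound 1 itself stands only at a limit. The expected step is a number no higher from compound 1 to compound 3 (the limit leaves the size open). Compound 3 is accordingly estimated at 10000 nM, within 3000 nM to 30000 nM, most likely again as a limit.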

Compound 3, half-maximal inhibitory concentration: 3700 nM
The estimate for compound 3 lay 2.7-fold (0.43 log units) above the measured number; measured number inside the range.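

In this assay, methyl in place of chloro on this aromatic carbon, next to the ring nitrogen, gives an at least 2.7-fold lower number from compound 1 to compound 3 (0.43 log units; beyond the scatter). That step is a minimum: compound 1 gives a limit, not a number. Among the three compounds, only compound 3 gives a number: the limit of > 10000 nM in this assay, at which 2 of the 3 values shown sit.

As far as these compounds go, whether an ethyl, a methoxy or an amine on this carbon would move the number further stays open. So does whether methyl in place of chloro gives a readable number when 1-((tert-butoxycarbonyl)amino)ethyl stands in place of 1-(tert-butoxycarbonyl)pyrrolidin-2-yl.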